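Cyano in place of hydrogen on the pyridine of compound 1

The source may hold more compounds than are shown below. What is called first, only, known or untested is meant among the compounds shown, and "the series" means these compounds.

Compound 1 `c1cncc(N2CC[C@@H]3CN[C@@H]3C2)c1` carries an unsubstituted pyridine on the shared core. In a functional assay on HEK293 cells for agonist activity at Neuronal acetylcholine receptor; alpha4/beta2 (Homo sapiens), read by FLIPR (a lower number here means that less compound is needed, a higher number that more compound is needed for the effect), compound 1 gives 330 nM, the higher of the two numbers measured. Compound 2 `Clc1ccc(N2CC[C@@H]3CN[C@@H]3C2)cn1` gives 24 nM, and the step of a 14-fold lower number from compound 1 to compound 2 (1.14 log units; beyond the scatter) shows that a single ring substituent can shift the number a great deal. Compound 3 `N#Cc1cncc(N2CC[C@@H]3CN[C@@H]3C2)c1` differs from compound 1 by cyano in place of hydrogen on an aromatic carbon. Because a 14-fold lower number from compound 1 to compound 2 (1.14 log units; beyond the scatter) was large but sat at another ring position, only a moderate gain is expected here, a 2.8-fold lower number from compound 1 to compound 3 (0.44 log units; beyond the scatter). Compound 3 is therefore estimated at 120 nM, within 40 nM to 400 nM.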

Compound 3, half-maximal effective concentration: 1900 nM
Beside the measured number, compound 3's estimate is 16-fold (1.20 log units) below it, outside the stated range (above it).
By their numbers in this assay, from the lowest: compound 2; then compound 1; then compound 3.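

In this assay, cyano on the aromatic carbon two atoms from the ring nitrogen moves the number upward (a 5.8-fold higher number from compound 1 to compound 3 (0.76 log units; beyond the scatter)), so more compound is needed for the effect. Set against the opposite step with chloro (a 14-fold lower number from compound 1 to compound 2 (1.14 log units; beyond the scatter)), this shows that adding a ring substituent to compound 1 does not by itself lower the number. Nothing measured here explains the rise. On these data alone, whether fluoro, methoxy or an amine on this same carbon would also raise the number remains open, as does what cyano would do at the ring position that carries chloro in compound 2.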